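A few compounds are considered here, and "the series" means these few. Any claim that something is new, unique, unknown or untested is made for them only; others in the source may bear on it.

The measured compounds:
compound 1, `O=Cc1ccc(-c2cncc(Cl)c2N2CCC3(CCNC3=O)CC2)o1`: 5190 nM
compound 2, `CCOCOCc1ccc(-c2cncc(Cl)c2N2CCC3(CCNC3=O)CC2)o1`: 2970 nM
compound 3, `O=C1NCCC12CCN(c1c(Cl)cncc1-c1ccc(CN3CCCC3)s1)CC2`: 3370 nM

All three were tested in a functional assay on MV4-11 cells (Homo sapiens) for inhibition, read by resazurin assay, with a stated time of 72 h; on this read-out higher numbers stand for weaker inhibition of growth and lower numbers for stronger inhibition of growth. Compound 1 has the highest of the three numbers, yet compound 3 lies closest to it and compound 2 farthest, and both gaps fall within the usual scatter, so the three cannot be told apart on these values. Within the data shown here, the only step among them, a 1.7-fold lower number from compound 1 to compound 2 (0.24 log units; within the scatter), swaps the group carried on the furan ring and also stays within the scatter.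

Compound 4, `O=Cc1cc(-c2cncc(Cl)c2N2CCC3(CCNC3=O)CC2)co1`, is not yet measured. It differs from compound 1 in one place: 5-formylfuran-3-yl in place of 5-formylfuran-2-yl on an aromatic carbon. The two have the same atoms, joined differently.

Among the measured compounds shown here, no measured step covers a change of this kind. For the measured compounds named here, the one step on this part of the molecule, a 1.7-fold lower number from compound 1 to compound 2 (0.24 log units; within the scatter), changes the group on the furan ring and says nothing about how the ring is joined to the shared core. No direction can therefore be read from the data, and a step that stays within the scatter is the expectation: a 1.1-fold higher number from compound 1 to compound 4 (0.03 log units; within the scatter). Compound 4 is thus estimated to give about 5500 nM, with a range from 2000 nM to 16000 nM. Going by the values given here, the range is kept wide: no step bears on this change.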

Compound 4, concentration for 50% growth inhibition: 5150 nM
Estimate against measurement, compound 4: 1.1-fold (0.03 log units) above; measured number inside the range.
By their numbers in this assay, from the lowest: compounds 2, 3, 4 and 1 (each within the scatter of the next).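

Moving the furan's point of attachment on an aromatic carbon of the six-membered aromatic ring with 1 nitrogen, with 5-formylfuran-3-yl in place of 5-formylfuran-2-yl, gives a 1.0-fold lower number from compound 1 to compound 4 (0.00 log units; within the scatter) in this assay. Among these compounds, the earlier step from the same starting compound changed the group carried on the furan, whereas this one keeps every atom and alters only how the ring is joined to the shared core, so it is the first direct reading of that kind of change. For this pair, the two ways of joining the formylfuran cannot be told apart on growth inhibition, and no outside measurement is available to explain the result.

As far as these compounds go, whether the two attachments would remain indistinguishable with a different group on the furan stays open, for example with a carboxylic acid or a primary amine in place of the formyl group. Also open, from the compounds shown here alone, is what would happen at this position with a ring of another kind, such as a phenyl ring bearing the same formyl group.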